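Swapping Methyl for Fluoro on the Outer Ring

A few compounds are considered here, and "the series" means these few. Any claim that something is new, unique, unknown or untested is made for them only; others in the source may bear on it.

Three compounds share one core. Compound 1 `O=c1[nH]cc(S(=O)(=O)Nc2ccccc2-c2cn(-c3ccccc3F)nn2)c(=O)[nH]1` gives 12500 nM in a functional assay on HepG2 cells (Homo sapiens) for antiproliferative activity, read by MTT assay, with a stated time of 24 h; on this read-out higher numbers stand for weaker inhibition and lower numbers for stronger inhibition. Compound 2 `O=c1[nH]cc(S(=O)(=O)Nc2cccc(-c3cn(-c4cccc(Cl)c4)nn3)c2)c(=O)[nH]1` gives 4200 nM in this assay. Compound 3 `Cc1ccccc1-n1cc(-c2ccc(NS(=O)(=O)c3c[nH]c(=O)[nH]c3=O)cc2)nn1` gives 14500 nM in this assay, the highest of the three numbers; its gap to compound 1 lies within the scatter, while compound 2 sits at a lower number beyond it. Compound 4 `O=c1[nH]cc(S(=O)(=O)Nc2ccc(-c3cn(-c4ccccc4F)nn3)cc2)c(=O)[nH]1` differs from compound 3 in one place: fluoro in place of methyl on an aromatic carbon. Among the measured compounds shown here, no measured pair shows this change on its own. Since compound 1 carries the same 2-fluorophenyl group and gives 12500 nM, a step no larger than the scatter is expected, in either direction. Compound 4 is therefore estimated at 12000 nM in this assay, with a range from 5000 nM to 30000 nM, which means an expected step of a 1.2-fold lower number from compound 3 to compound 4 (0.08 log units; within the scatter).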

Compound 4, half-maximal inhibitory concentration: > 20000 nM
Compound 4: only a limit was reported; the forecaster's own chance of this, stated with the estimate: 10%; middle value at least 1.6-fold (0.22 log units) from the limit.
By their numbers in this assay, from the lowest: compound 2; then compounds 1 and 3 (each within the scatter of the next). At a limit, above all of these: compound 4.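

At this position on the outer ring, fluoro in place of methyl brings no stronger inhibition. In this assay the change gives an at least 1.3-fold higher number from compound 3 to compound 4 (0.13 log units; that floor lies within the scatter). The result for compound 4 is a limit, not a number: the limit of > 20000 nM in this assay, at which 1 of the 4 values shown sits.

Going by these compounds, the true size of the step therefore stays open, since only its floor can be read, and that floor does not separate the two compounds. Also open, on these data alone, is whether an amine or a methoxy group at this position would give stronger inhibition than methyl or fluoro.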